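Adding a Hydroxyethyl Arm to a Rapidly Cleared Compound

The source may hold more compounds than are shown below. What is called first, only, known or untested is meant among the compounds shown, and "the series" means these compounds.

In an ADME assay on cells (Hepatocyte, Rattus norvegicus, strain Wistar) for pharmacokinetics, read by LC-MS, with a stated time of 90 min, tested at 1 uM (a higher number here means faster removal of the compound, a lower number slower removal), compound 1 (`COc1cc(C(=O)N2CC[C@@H](O)[C@H](C)C2)cc2nc(NCc3cccc(Cl)c3)oc12`) gives 38.3 mL/min/kg. Among the compounds with values here, this is the higher of only two numbers so far, and the gap lies beyond the usual scatter of repeated measurements: compound 2 (`COc1cc(C(=O)N2CCC(O)C(C)C2)cc2nc(NCc3cc(Cl)ccn3)oc12`) gives 14.3 mL/min/kg. Compound 3 (`COc1cc(C(=O)N2CC(C)C(O)CC2CCO)cc2nc(NCc3cccc(Cl)c3)oc12`), not yet measured, keeps the core of compound 1 but carries 4-hydroxy-2-(2-hydroxyethyl)-5-methylpiperidin-1-yl in place of 4-hydroxy-3-methylpiperidin-1-yl on a carbonyl carbon. Within the data shown here, no measured compound carries this new group, and the two measured compounds offer no single-change comparison, so the expectation is cautious. A slightly lower number is expected in this assay, though not a change beyond the scatter, with the estimated step of a 1.4-fold lower number from compound 1 to compound 3 (0.15 log units; within the scatter). For compound 3 the estimate is 27 mL/min/kg, with an expected range of 13 mL/min/kg to 52 mL/min/kg.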

Compound 3, clearance: 4.5 mL/min/kg
For compound 3 the middle estimate is 6.0-fold (0.78 log units) above the measured one; the whole stated range lies above it.
By their numbers in this assay, from the lowest: compound 3; then compound 2; then compound 1.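

In this assay, the group on the carbonyl carbon proves to matter a great deal: putting 4-hydroxy-2-(2-hydroxyethyl)-5-methylpiperidin-1-yl in place of 4-hydroxy-3-methylpiperidin-1-yl gives an 8.5-fold lower number from compound 1 to compound 3 (0.93 log units; beyond the scatter). Within the data shown here, this is the first comparison here in which only one place changes, so it shows that this group alone, with the shared core held fixed, can move clearance this far. No measurement shown gives a reason for the drop.

As far as these compounds go, it remains open whether the whole hydroxyethyl arm is needed, and a plain ethyl arm, a longer chain or an amine in place of the arm's hydroxyl would each test a different part of it. From the compounds shown here alone, it also remains open whether the same change would give a similar step on compound 2, which differs from compound 1 in another place too.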